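The source may report more compounds than this note shows. Statements on the series, on what has been measured and on what is new or still open speak of the compounds shown alone.

Working notes on the series, followed through the step from compound 3 to compound 4.

Compound 1 `CN1CCCC(NC(=O)c2ccc(C(F)(F)F)cc2)(c2ccccc2)C1` sits at a limit in an assay on cells for inhibition of sodium- and chloride-dependent glycine transporter 1 (Homo sapiens); a higher number here means that more compound is needed for the effect, a lower number that less compound is needed: compound 1 gives > 10000 nM, a limit and not a number (the limit of > 10000 nM in this assay, at which 1 of the 3 values shown sits). Compound 2 `CN1CCCC(NC(=O)c2ccc(C(F)(F)F)cc2Br)(c2ccccc2)C1` gives 300 nM in this assay. Between them, an at least 33-fold lower number from compound 1 to compound 2 (1.52 log units; beyond the scatter) is the single measured step here, and it lies on the benzamide ring. Compound 3 `COc1cc(C(F)(F)F)cc(SC)c1C(=O)NC1(c2ccc(Cl)cc2)CCCN(C)C1` gives 28 nM in this assay, the lowest of the two numbers, and compound 2 stands nearest to it, as the two values themselves show.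

Compound 4 `COc1cccc(C2(NC(=O)c3c(OC)cc(C(F)(F)F)cc3SC)CCCN(C)C2)c1` differs from compound 3 by 3-methoxyphenyl in place of 4-chlorophenyl on a saturated ring carbon. Among the compounds with values here, no measured step touches the aryl group on that saturated ring carbon; the one step available concerns a change on the other aromatic ring, so it gives no direct guidance on size or direction. With that, only a moderate shift, not beyond the scatter in either direction with confidence, is expected for compound 4 in this assay, a 1.8-fold higher number from compound 3 to compound 4 (0.25 log units; within the scatter). The estimate for compound 4 in this assay is 50 nM, with a range from 12 nM to 250 nM.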

Compound 4, half-maximal effective concentration: 110 nM
The estimate for compound 4 lay 2.2-fold (0.34 log units) below the measured number; low and high end bracket the measured number.
By their numbers in this assay, from the lowest: compound 3; then compound 4; then compound 2. At a limit, above all of these: compound 1.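

The aryl group on the saturated ring carbon, untouched by the earlier measured step, now proves to matter in this assay: a 3.9-fold higher number from compound 3 to compound 4 (0.59 log units; beyond the scatter), with the rest of the structure held constant. The position therefore responds to substitution on this aryl group, although the size of this one step is modest and compound 4 keeps a measurable value rather than falling to a limit. The change from 4-chlorophenyl to 3-methoxyphenyl alters both the substituent and its ring position, so this single pair cannot separate the two.

As far as these compounds go, it remains open how a pyridine ring or a cyclohexyl group would behave in place of this aryl group. Nothing measured here gives a reason for the step from compound 3 to compound 4.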